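This account rests on a few compounds, and the source may have more. Where it says the series, first, only, none or still open, it means among the compounds named here.

Series notes. Of the compounds shown here, three on the shared core have been measured. Compound 1 `OC[C@H]1O[C@@H](n2cnc3c(SCC4CCCCC4)ncnc32)[C@H](O)[C@@H]1O` gives 1550 nM in an assay on isolated protein for binding affinity to Equilibrative nucleoside transporter 1 (Homo sapiens); on this read-out lower numbers stand for stronger inhibition and higher numbers for weaker inhibition; compound 2 `OC[C@H]1O[C@@H](n2cnc3c(CSc4ccccc4Cl)ncnc32)[C@H](O)[C@@H]1O` gives 1780 nM in this assay; compound 3 `OC[C@H]1O[C@@H](n2cnc3c(CSc4cccc(Br)c4)ncnc32)[C@H](O)[C@@H]1O` gives 363 nM in this assay. Compound 3 stands lowest of the three, with a 4.3-fold lower number from compound 1 to compound 3 (0.63 log units; beyond the scatter) and a 4.9-fold lower number from compound 2 to compound 3 (0.69 log units; beyond the scatter) both beyond the scatter, while a 1.1-fold higher number from compound 1 to compound 2 (0.06 log units; within the scatter) lies within it. Compound 4 `OC[C@H]1O[C@@H](n2cnc3c(CSc4ccc(Br)cc4)ncnc32)[C@H](O)[C@@H]1O` is not yet measured; it differs from compound 3 by 4-bromophenyl in place of 3-bromophenyl on a sulfur. Among the measured compounds shown here, the only measured step that changes the ring on the sulfur is a 4.9-fold lower number from compound 2 to compound 3 (0.69 log units; beyond the scatter), which also swaps the halogen, so it bears only loosely on this move. A small step in this assay is expected, a 1.2-fold higher number from compound 3 to compound 4 (0.09 log units; within the scatter), probably not beyond the scatter. Compound 4 is therefore estimated at 450 nM, with a range of 150 nM to 1500 nM.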

Compound 4, half-maximal inhibitory concentration: 178 nM
Compound 4: the middle estimate sits 2.5-fold (0.40 log units) above what was measured; the measured number falls inside the stated range.
By their numbers in this assay, from the lowest: compound 4; then compound 3; then compounds 1 and 2 (each within the scatter of the next).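

In this assay, 4-bromophenyl in place of 3-bromophenyl on the sulfur gives a 2.0-fold lower number from compound 3 to compound 4 (0.31 log units; beyond the scatter), so the bromine's placement counts by itself, which the earlier step, with its halogen swap, could not separate. Among the compounds shown here, the same group gives the largest steps so far, a 10-fold lower number from compound 2 to compound 4 (1.00 log units; beyond the scatter) and an 8.7-fold lower number from compound 1 to compound 4 (0.94 log units; beyond the scatter). No supporting data explain these differences. As far as these compounds go, whether 4-chlorophenyl or 4-methoxyphenyl would match 4-bromophenyl remains open. So does whether a 4-aminophenyl group on the sulfur would hold this level.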